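Amide variation on a trimethoxyphenyl benzylamide series

A few compounds are considered here, and "the series" means these few. Any claim that something is new, unique, unknown or untested is made for them only; others in the source may bear on it.

Measured compounds:
compound 1 `CCC/C=C/C(=O)N(Cc1ccc(OC)c(O)c1)c1cc(OC)c(OC)c(OC)c1`: 57 nM
compound 2 `COc1ccc(CN(C(C)=O)c2cc(OC)c(OC)c(OC)c2)cc1O`: 160 nM
compound 3 `COc1ccc(CN(C(=O)/C=C/CBr)c2cc(OC)c(OC)c(OC)c2)cc1O`: 100 nM

All three share one core and differ only in the group on the carbonyl carbon. In a functional assay on KYSE-450 cells (Homo sapiens) for inhibition, read by MTT assay, with a stated time of 48 h (a lower number here means a stronger inhibitor, a higher number a weaker inhibitor), compound 3 gives 100 nM and stands second highest of the three numbers; its nearest neighbour is compound 2, and the gap between them lies within the scatter, as does the gap to compound 1.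

The next compound in the series is compound 4 `COc1ccc(CN(C(=O)CO)c2cc(OC)c(OC)c(OC)c2)cc1O`. It differs from compound 3 in one place: hydroxymethyl in place of 3-bromoprop-1-en-1-yl on a carbonyl carbon

Among the measured compounds shown here, two measured steps bear on this change. Replacing the alkenyl chain with a small group gave a 2.8-fold higher number from compound 1 to compound 2 (0.45 log units; beyond the scatter), a modest rise. Putting a bromo-substituted alkenyl chain back in gave a 1.6-fold lower number from compound 2 to compound 3 (0.20 log units; within the scatter), within the scatter. A hydroxymethyl is a small group like methyl, so compound 4 is expected to sit near compound 2, with at most a small move in this assay toward a higher number; the expected step is a 1.8-fold higher number from compound 3 to compound 4 (0.26 log units; within the scatter).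

The estimate for compound 4 in this assay is 180 nM, with a range from 80 nM to 400 nM.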

Compound 4, half-maximal inhibitory concentration: 370 nM
For compound 4 the middle estimate is 2.1-fold (0.31 log units) below the measured one; measured number inside the range.
By their numbers in this assay, from the lowest: compounds 1, 3 and 2 (each within the scatter of the next, the first and the last beyond it); then compound 4.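

In this assay, compound 4 has the highest number of the four, and its gap to each earlier compound lies beyond the scatter: a 3.7-fold higher number from compound 3 to compound 4 (0.57 log units; beyond the scatter), and a 6.5-fold higher number from compound 1 to compound 4 (0.81 log units; beyond the scatter). The new information comes from the comparison with the methyl of compound 2, a 2.3-fold higher number from compound 2 to compound 4 (0.36 log units; beyond the scatter), which shows that a hydroxy in place of hydrogen on the saturated chain carbon bound to the carbonyl carbon moves the number on its own, so a small group at this position does not fix a single level. No measurement among the data shown gives a reason for this rise.

From the compounds shown here alone, whether the rise belongs to the hydroxy itself or would follow any similar replacement on this chain carbon remains open; a methoxymethyl, an aminomethyl or a carboxylic acid at the same place would bear on that. Also open, going by these compounds, is whether a hydroxy placed on a longer chain, such as 3-hydroxyprop-1-en-1-yl in place of the 3-bromoprop-1-en-1-yl of compound 3, would give a similar step or leave the number close to that of compound 3.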